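Compound 3 to compound 4: a longer methylcarbamoyl chain

The compounds below may be only part of what the source reports. "The series", "measured", "known", "first", "only" and "open" are said of these compounds alone.

For the measured compounds named here, in a functional assay on MDA-MB-231 cells (Homo sapiens) for inhibition, read by MTT assay, with a stated time of 72 h (on this read-out higher numbers stand for weaker inhibition and lower numbers for stronger inhibition), compound 3 (`Nc1nc2cc(-c3nn(CC(=O)NO)c4ncnc(N)c34)ccc2o1`) gives 6310 nM and holds the lowest number of the series so far. Compound 1 (`CNC(=O)CCCCCCCn1nc(-c2cnc3[nH]ccc3c2)c2c(N)ncnc21`) stands at 15800 nM and compound 2 (`Nc1nc2cc(-c3nn(CCCC(=O)NO)c4ncnc(N)c34)ccc2o1`) at 19500 nM in this assay and both lie beyond the scatter from compound 3.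

The change to compound 4 (`CNC(=O)CCCCCCCn1nc(-c2ccc3oc(N)nc3c2)c2c(N)ncnc21`) is 6-(methylcarbamoyl)hexyl in place of hydroxycarbamoyl on a saturated chain carbon bound to an aromatic nitrogen on the core of compound 3: 6-(methylcarbamoyl)hexyl in place of hydroxycarbamoyl. Going by the values given here, the one measured step at this place is a 3.1-fold lower number from compound 2 to compound 3 (0.49 log units; beyond the scatter) and it is modest, with the shorter group on the lower number. Among the compounds with values here, no measured pair isolates the loss of the hydroxycarbamoyl end. Compound 1 already carries 6-(methylcarbamoyl)hexyl on another core and sits at 15800 nM there.

A modest rise is therefore expected in this assay with a 2.4-fold higher number from compound 3 to compound 4 (0.38 log units; beyond the scatter) as the estimated step. For compound 4 the estimated value is 15000 nM with an expected range of 6000 nM to 40000 nM for now.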

Compound 4, half-maximal inhibitory concentration: 2900 nM
For compound 4 the middle estimate is 5.2-fold (0.71 log units) above the measured one; the whole stated range lies above it.
By their numbers in this assay, from the lowest: compound 4; then compound 3; then compounds 1 and 2 (each within the scatter of the next).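

In this assay, the long 6-(methylcarbamoyl)hexyl chain on a saturated chain carbon bound to an aromatic nitrogen is tolerated without a hydroxycarbamoyl end, with a 2.2-fold lower number from compound 3 to compound 4 (0.34 log units; beyond the scatter) on the shared core. The earlier link between a shorter group and a lower number therefore does not extend to the whole set: the longest chain holds the lowest number, and the change at this place gives a 6.7-fold lower number from compound 2 to compound 4 (0.83 log units; beyond the scatter) as well. With the chain held constant, the group on the aromatic carbon of the core also counts, at a 5.4-fold lower number from compound 1 to compound 4 (0.74 log units; beyond the scatter) in this read-out.

A 6-(hydroxycarbamoyl)hexyl chain or a chain ending in a carboxylic acid on the same core would separate chain length from the end group, a question these compounds leave open. Nothing on hand gives a cause for any of these steps.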